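Hydroxy to Methoxy on a Shared Core

This account rests on a few compounds, and the source may have more. Where it says the series, first, only, none or still open, it means among the compounds named here.

The measured compounds, all tested in a functional assay on HCC 2998 cells (Homo sapiens) for inhibition, read by sulforhodamine B assay, with a stated time of 48 h, tested at 10 uM; a higher number here means a weaker effect of the compound at the concentration tested, a lower number a stronger effect:
Compound 1 `O=C(Nc1cccc(-n2cc(-c3ccncc3)c(-c3cc(O)cc(Cl)c3)n2)c1)Nc1ccc(Cl)c(C(F)(F)F)c1`, which in this assay gives 34.3%.
Compound 2 `O=C(Nc1cccc(-n2cc(-c3ccncc3)c(-c3cc(O)cc(Cl)c3)n2)c1)Nc1ccc(Cl)c(Cl)c1`, which in this assay gives 0.57%.
Compound 3 `COc1cc(Cl)cc(-c2nn(-c3cccc(NC(=O)Nc4cc(C(F)(F)F)cc(C(F)(F)F)c4)c3)cc2-c2ccncc2)c1`, which in this assay gives 9.5%.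

Compound 2 holds the lowest number of the three. Going by the values given here, compound 3 sits nearest, within the scatter of repeated measurement, so the two cannot be ordered; compound 1 lies far above it, and the step of a number 33.7 percentage points lower from compound 1 to compound 2 (beyond the scatter) is the only single-point change measured so far. Compound 4 `COc1cc(Cl)cc(-c2nn(-c3cccc(NC(=O)Nc4ccc(Cl)c(Cl)c4)c3)cc2-c2ccncc2)c1` differs from compound 2 in one place: methyl in place of hydrogen on an oxygen on an aromatic ring. Among the compounds with values here, no measured step touches this change. Within the data shown here, compound 3 already carries the methoxy together with a different urea substituent, and it differs from compound 2 in two places, so its value tells only that a methoxy-bearing compound can give a low number. Nothing in the data points to a step beyond the scatter. Compound 4 is therefore expected near compound 2, with an estimated step of a number 4.4 percentage points higher from compound 2 to compound 4 (within the scatter), giving an estimate of 5% with a range from 0% to 25%.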

Compound 4, a percentage reported as activity, at one concentration (the size of the read-out at that concentration, not a potency): 26.7%
Estimate against measurement, compound 4: 21.7 percentage points below, outside the stated range (above it).
By their numbers in this assay, from the lowest: compounds 2 and 3 (each within the scatter of the next); then compounds 4 and 1 (each within the scatter of the next).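

In this assay, methyl in place of hydrogen on this oxygen is not a silent change: the hydroxy to methoxy swap gives a number 26.1 percentage points higher from compound 2 to compound 4 (beyond the scatter) and so shows that this position responds to substitution. Going by these compounds alone, the earlier compounds could not show this, as their only single-place step, chloro in place of trifluoromethyl, lay in the urea substituent. Nothing available explains the rise in the number, and no measurement bears on its cause.

As far as these compounds go, whether an ethoxy group, an amine or a carboxylic acid in place of the hydroxy would keep the number of compound 2 or raise it as the methoxy does remains open. So does whether the hydroxy to methoxy step keeps its size when the urea substituent carries trifluoromethyl groups.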